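Isopropyl for propyl in compound 2

The source may report more compounds than this note shows. Statements on the series, on what has been measured and on what is new or still open speak of the compounds shown alone.

In an ADME assay on the whole organism for inhibition, with Echinochloa crus-galli var. formosensis as the target, with a stated time of 4 days (a higher number here means a weaker inhibitor, a lower number a stronger inhibitor), compound 2 `CCCNc1nc(Cl)nc(N[C@H](C)c2ccccc2)n1` gives 33100 nM as the highest of three numbers. Compound 1 `CCCNc1nc(Cl)nc(N[C@@H](C)c2ccccc2)n1` gives 15100 nM and compound 3 `CCCN(CC)c1nc(Cl)nc(N[C@@H](C)c2ccccc2)n1` gives 282 nM on the same scale. Compound 4 `CC(C)Nc1nc(Cl)nc(N[C@H](C)c2ccccc2)n1` keeps the configuration of compound 2 and differs by isopropyl in place of propyl on a nitrogen on an aromatic ring as isopropyl in place of propyl on a nitrogen on an aromatic ring. Among the compounds with values here, no measured step changes this chain itself. The nearest guide is a 54-fold lower number from compound 1 to compound 3 (1.73 log units; beyond the scatter) as a large change on such a nitrogen, while a 2.2-fold higher number from compound 1 to compound 2 (0.34 log units; beyond the scatter) is modest and rests on the fact that compounds 1 and 2 differ only in the configuration as drawn alone. A modest shift to a lower number is therefore expected, well short of that large change. The estimated move is a 1.7-fold lower number from compound 2 to compound 4 (0.22 log units; within the scatter) and no more. In this assay compound 4 is estimated at 20000 nM (expected range 5000 nM to 70000 nM).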

Compound 4, half-maximal inhibitory concentration: 2000 nM
The estimate for compound 4 lay 10-fold (1.00 log units) above the measured number; measured number below the stated range.
By their numbers in this assay, from the lowest: compound 3; then compound 4; then compound 1; then compound 2.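

In this assay, the step from propyl to isopropyl on a nitrogen on an aromatic ring is large, although the two compounds have the same atoms, joined differently: a 17-fold lower number from compound 2 to compound 4 (1.22 log units; beyond the scatter). Earlier, this nitrogen had shown a large step only with an added ethyl; now the arrangement of the chain alone also moves the number. Nothing given here accounts for this step. On these data alone, whether isopropyl gives a similar step in the configuration of compound 1 remains open, as does the outcome with a tert-butyl or cyclopropyl group on this nitrogen.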